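The source may hold more compounds than are shown below. What is called first, only, known or untested is meant among the compounds shown, and "the series" means these compounds.

Measured so far:
compound 1 `CC(=O)N1N=C(c2ccco2)CC1c1ccc([N+](=O)[O-])cc1` — 21300 nM
compound 2 `O=CCN1N=C(c2ccc3ccccc3c2)CC1c1ccccc1` — 7400 nM

In a functional assay on PC-3 cells (Homo sapiens) for cytotoxicity, read by sulforhodamine B assay, with a stated time of 48 h (on this read-out higher numbers stand for weaker inhibition and lower numbers for stronger inhibition), compound 2 gives the lower of the two numbers, compound 1 standing a good deal higher, beyond the scatter. Compound 3 `COc1ccc(C2CC(c3ccc4ccccc4c3)=NN2CC=O)cc1` is not yet measured. Against compound 2 it carries methoxy in place of hydrogen on an aromatic carbon, methoxy in place of hydrogen on an aromatic carbon, a change for which no measured pair exists in this set. The step from compound 2 to compound 3 is expected to be small, in either direction or none beyond the scatter, as a 1.2-fold lower number from compound 2 to compound 3 (0.09 log units; within the scatter). Compound 3 is estimated at 6000 nM, within 2500 nM to 15000 nM.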

Compound 3, half-maximal inhibitory concentration: 4530 nM
The estimate for compound 3 lay 1.3-fold (0.12 log units) above the measured number, within the range that was stated.
By their numbers in this assay, from the lowest: compounds 3 and 2 (each within the scatter of the next); then compound 1.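

In this assay the change from phenyl to 4-methoxyphenyl gives a 1.6-fold lower number from compound 2 to compound 3 (0.21 log units; within the scatter) and so shows that this place, para to a large group, accepts methoxy with no step beyond the scatter. Within the data shown here, this is the first pair that differs in one place, and it speaks for this one substituent on this one ring. No measurement on hand bears on the reason for the step.

Still open, as far as these compounds go, is whether an amine, a carboxylic acid or a longer ethoxy chain at the same place would stay within the scatter of compound 2. Also open, from the compounds shown here alone, is whether methoxy reads the same way on the core of compound 1.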